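An amino group added to compound 2

This account rests on a few compounds, and the source may have more. Where it says the series, first, only, none or still open, it means among the compounds named here.

Three measured compounds share one core and differ in the group on the amide carbonyl. In a functional assay on A2780 cells (Homo sapiens) for antiproliferative activity, read by CellTiter-Glo, with a stated time of 72 h (on this read-out lower numbers stand for stronger inhibition and higher numbers for weaker inhibition), compound 1 `C[C@H](NC(=O)c1cccc(F)c1)c1ccc(NC(=O)N2CC(c3cccnc3)C2)cc1` gives 2.3 nM, compound 2 `C[C@H](NC(=O)c1ncccn1)c1ccc(NC(=O)N2CC(c3cccnc3)C2)cc1` gives 36 nM and compound 3 `CCC(=O)N[C@@H](C)c1ccc(NC(=O)N2CC(c3cccnc3)C2)cc1` gives 25 nM. Compound 1 is the most potent of the three, while compound 2 sits level with compound 3, since a 1.4-fold lower number from compound 2 to compound 3 (0.16 log units; within the scatter) lies within the scatter.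

Compound 4 `C[C@H](NC(=O)c1ncccn1)c1ccc(NC(=O)N2CC(c3cncc(N)c3)C2)cc1` keeps the carbonyl side of compound 2 and turns pyridin-3-yl into 5-aminopyridin-3-yl, which places amino in place of hydrogen on an aromatic carbon.

Within the data shown here, no measured step touches this ring, so there is no direct evidence for the effect of the change. Among the measured compounds shown here, the steps at the carbonyl, a 16-fold higher number from compound 1 to compound 2 (1.19 log units; beyond the scatter) and an 11-fold higher number from compound 1 to compound 3 (1.04 log units; beyond the scatter), are both large, and they show only that one change can move the number far. They give no direction for an amino group. With so little to go on, a modest change is the best guess, and the expected result is a 1.4-fold higher number from compound 2 to compound 4 (0.14 log units; within the scatter) in this assay. For compound 4 the estimated value is 50 nM, with an expected range from 10 nM to 300 nM.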

Compound 4, half-maximal inhibitory concentration: 340 nM
Beside the measured number, compound 4's estimate is 6.8-fold (0.83 log units) below it; the whole stated range lies below it.
By their numbers in this assay, from the lowest: compound 1; then compounds 3 and 2 (each within the scatter of the next); then compound 4.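

Placing amino in place of hydrogen on this aromatic carbon gives, in this assay, a 9.4-fold higher number from compound 2 to compound 4 (0.98 log units; beyond the scatter) and so weakens inhibition well beyond the usual scatter. Among these compounds, until now every measured change sat at the carbonyl, so this is the first sign that the pyridin-3-yl end of the molecule also matters to the number, and that the position does not tolerate every addition. A change of just 1 heavy atom here acts on the same broad scale as replacing a whole group at the carbonyl, as in a 16-fold higher number from compound 1 to compound 2 (1.19 log units; beyond the scatter) where the swap is far larger, yet nothing shown explains the loss.

From the compounds shown here alone, it remains open whether a methyl, a methoxy or a fluorine on the same carbon would move the number in the same way, or whether the step belongs to amino alone. It is also open whether the step would carry over with other groups on the carbonyl, such as the 3-fluorophenyl of compound 1 or the ethyl of compound 3, as amino is shown here only alongside the pyrimidin-2-yl of compound 2.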